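The source may hold more compounds than are shown below. What is called first, only, known or untested is meant among the compounds shown, and "the series" means these compounds.

Measured in a functional assay on cells for positive allosteric modulation of metabotropic glutamate receptor 5 (Rattus norvegicus), read by calcium flux; on this read-out lower numbers stand for an effect already at smaller amounts and higher numbers for an effect only at larger amounts of compound:
compound 1 `COc1ccc(C(=O)Nc2cc(-c3ccccc3)nn2-c2ccccc2)cc1` gives 54 nM
compound 2 `COc1cccc(-c2cc(NC(=O)c3ccccc3)n(-c3ccccc3)n2)c1` gives 600 nM
compound 3 `O=C(Nc1cc(-c2ccccc2)nn1-c1ccccc1Br)c1ccccc1` gives 200 nM

Among these three numbers in this assay, compound 1 holds the lowest. Compound 3 stands nearest to it, its number already beyond the scatter; compound 2 stands furthest, well beyond the scatter. Neither pair differs in a single place, so no one-step comparison is available from them.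

Compound 4 `O=C(Nc1cc(-c2ccccc2)nn1-c1ccccc1)c1ccncc1` is not yet measured. It differs from compound 1 by pyridin-4-yl in place of 4-methoxyphenyl on a carbonyl carbon. No change of this kind appears between measured compounds, so its size is a guess from the structural change alone. For compound 4 the expected outcome is a moderate rise in number, a 2.8-fold higher number from compound 1 to compound 4 (0.44 log units; beyond the scatter). In this assay compound 4 is estimated at 150 nM, with a range from 40 nM to 600 nM.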

Compound 4, half-maximal effective concentration: 2500 nM
Beside the measured number, compound 4's estimate is 17-fold (1.22 log units) below it; the measured number lies above the stated range.
By their numbers in this assay, from the lowest: compound 1; then compound 3; then compound 2; then compound 4.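

Pyridin-4-yl in place of 4-methoxyphenyl on a carbonyl carbon gives a 46-fold higher number from compound 1 to compound 4 (1.67 log units; beyond the scatter) in this assay and provides the first one-place comparison in the series. This position therefore responds strongly to this change, although both groups have one six-membered aromatic ring, 0 hydrogen-bond donors, 1 hydrogen-bond acceptor and no net charge. No measured evidence bears on the reason for this step.

The compounds shown leave open whether the ring nitrogen or the loss of methoxy drives the step. Pyridin-3-yl or 4-chlorophenyl at this place would help separate these two changes.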